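Swapping the Amide Aryl Group and Expected Clearance

This account rests on a few compounds, and the source may have more. Where it says the series, first, only, none or still open, it means among the compounds named here.

Compound 1 `CN1C[C@H](C(=O)Nc2ccc(C(F)(F)F)cc2)[C@@H](c2ccc(/C=C/C(=O)Nc3ccccc3N)cc2)C1` was tested in an in vitro ADME assay on microsomes from liver (Homo sapiens) for pharmacokinetics, read by LC-MS, with a stated time of 10 min, tested at 1 uM (on this read-out lower numbers stand for slow clearance and higher numbers for fast clearance), where compound 1 gives 6 mL/min/kg, the lowest of the three numbers shown. Compound 2 `Cc1cc(NC(=O)[C@H]2CN(C)C[C@@H]2c2ccc(/C=C/C(=O)Nc3ccccc3N)cc2)ccc1F` gives 15 mL/min/kg and compound 3 `CN1C[C@H](C(=O)Nc2ccc(Cl)c(Cl)c2)[C@@H](c2ccc(/C=C/C(=O)Nc3ccccc3N)cc2)C1` gives 14 mL/min/kg. Compound 4 `Cc1ccc(NC(=O)[C@H]2CN(C)C[C@@H]2c2ccc(/C=C/C(=O)Nc3ccccc3N)cc2)cn1` carries the change (6-methylpyridin-3-yl in place of 4-(trifluoromethyl)phenyl on an amide-type nitrogen). Going by the values given here, two measured steps bear on it, each replacing the same group at the same place: a 2.5-fold higher number from compound 1 to compound 2 (0.40 log units; beyond the scatter) and a 2.3-fold higher number from compound 1 to compound 3 (0.37 log units; beyond the scatter). Among the compounds with values here, both swaps of the group on the amide-type nitrogen gave modest rises of similar size, so a modest rise beyond the scatter is expected for compound 4 as well, though no measured step shows this particular group. The step expected is a 1.8-fold higher number from compound 1 to compound 4 (0.26 log units; within the scatter). Compound 4 is therefore expected to give 11 mL/min/kg, in a range from 5 mL/min/kg to 22 mL/min/kg.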

Compound 4, clearance: 8 mL/min/kg
The estimate for compound 4 lay 1.4-fold (0.14 log units) above the measured number; measured number inside the range.
By their numbers in this assay, from the lowest: compounds 1, 4, 3 and 2 (each within the scatter of the next, the first and the last beyond it).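

In this assay, 6-methylpyridin-3-yl, the only group shown with a ring nitrogen, stays within the scatter of all three other groups on the amide-type nitrogen (a 1.3-fold higher number from compound 1 to compound 4 (0.12 log units; within the scatter); a 1.8-fold lower number from compound 3 to compound 4 (0.24 log units; within the scatter); a 1.9-fold lower number from compound 2 to compound 4 (0.27 log units; within the scatter)). This position therefore takes a ring with a hetero atom in place of a ring of carbon only, with no step beyond the scatter, and compound 4 sits within the scatter of both compound 1 and compound 2, though those two lie beyond it from each other. Nothing measured here explains this result. Still open, on these data alone, is how a pyridin-3-yl ring without the methyl would read at this place, which would help separate the part played by the ring nitrogen from that of the methyl. Also open, as far as these compounds go, is how a phenyl ring carrying an amine or a carboxylic acid would read.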